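The source may hold more compounds than are shown below. What is called first, only, known or untested is meant among the compounds shown, and "the series" means these compounds.

In a functional assay on Bel7402/5-FU cells (Homo sapiens) for antiproliferative activity, read by MTT assay, with a stated time of 72 h (on this read-out higher numbers stand for weaker inhibition and lower numbers for stronger inhibition), compound 1 `C=C1C(=O)O[C@H]2[C@H]1CC/C(Cn1cc(Cn3cc(F)c(=O)n(Cc4ccc(F)cc4)c3=O)nn1)=C\CC[C@@]1(C)O[C@@H]21` gives 4860 nM and compound 2 `C=C1C(=O)O[C@H]2[C@H]1CC/C(COC(=O)Cn1cc(F)c(=O)n(Cc3ccc(F)cc3)c1=O)=C\CC[C@@]1(C)O[C@@H]21` gives 1140 nM under the same conditions. Compound 2 therefore has the lower of the two numbers and the stronger inhibition, by a margin beyond the usual scatter. Compound 3 `C=C1C(=O)O[C@H]2[C@H]1CC/C(COC(=O)Cn1cc(F)c(=O)n(Cc3ccc(C(F)(F)F)cc3)c1=O)=C\CC[C@@]1(C)O[C@@H]21` differs from compound 2 in one place: trifluoromethyl in place of fluoro on an aromatic carbon, para to a large group (trifluoromethyl in place of fluoro on an aromatic carbon). Within the data shown here, no measured pair of compounds shows what this kind of change does, so the expectation rests on compound 2 at 1140 nM alone. In this assay a step no larger than the scatter is expected, with only a slight lean towards a higher number. The estimated change is a 1.1-fold higher number from compound 2 to compound 3 (0.06 log units; within the scatter) and counts as small. Compound 3 is expected to give about 1300 nM with 500 nM to 3400 nM as the likely range.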

Compound 3, half-maximal inhibitory concentration: 2250 nM
Compound 3: middle estimate off by 1.7-fold (0.24 log units), on the low side; the measured number falls inside the stated range.
By their numbers in this assay, from the lowest: compounds 2 and 3 (each within the scatter of the next); then compound 1.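

In this assay, the change from 4-fluorobenzyl to 4-(trifluoromethyl)benzyl gives a 2.0-fold higher number from compound 2 to compound 3 (0.30 log units; within the scatter). Among these compounds, this is the first look at this position, on an aromatic carbon para to a large group, and it shows that trifluoromethyl, with 4 heavy atoms in place of the 1 of fluoro, leaves a difference that cannot be told apart from the variation between repeated measurements. No supporting data are available to explain this result.

With only fluoro and trifluoromethyl shown at this position, it remains open what an amine, a carboxylic acid or a longer chain such as butyl would do there. On these data alone, it is also open whether the same swap would give a similar step on compound 1, which joins the shared core to the rest of the molecule differently.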